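Swapping the sulfur-linked arm for a pyrimidinyl ether

A few compounds are considered here, and "the series" means these few. Any claim that something is new, unique, unknown or untested is made for them only; others in the source may bear on it.

Three compounds share one core and differ only in the group on a saturated chain carbon bound to a carbonyl carbon. In a functional assay on Jurkat cells (Homo sapiens) for inhibition (a higher number here means a weaker inhibitor, a lower number a stronger inhibitor), compound 1 `CC(C)[C@H](NC(=O)COc1cccc2ccccc12)C(=O)N[C@@H](CC(=O)O)C(=O)CSc1nnc(-c2ccccc2)o1` gives 150000 nM and compound 2 `Cc1nnc(SCC(=O)[C@H](CC(=O)O)NC(=O)[C@@H](NC(=O)COc2cccc3ccccc23)C(C)C)s1` gives 190000 nM. For compound 3 `CC(C)[C@H](NC(=O)COc1cccc2ccccc12)C(=O)N[C@@H](CC(=O)O)C(=O)CSc1nc2ccccc2o1` this assay reports only a limit, > 200000 nM, and no number. So compound 3 sits at the weak end of what the assay can report, as shown by the limit of > 200000 nM in this assay, at which 1 of the 3 values shown sits.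

Compound 4 `CC(C)[C@H](NC(=O)COc1cccc2ccccc12)C(=O)N[C@@H](CC(=O)O)C(=O)COc1ccnc(C(F)(F)F)n1` differs from compound 3 by (2-(trifluoromethyl)pyrimidin-4-yl)oxy in place of (1,3-benzoxazol-2-yl)sulfanyl on a saturated chain carbon bound to a carbonyl carbon. The measured steps all exchanged one heteroaryl on the sulfur for another, and none moved the read-out beyond the scatter: a 1.3-fold higher number from compound 1 to compound 2 (0.10 log units; within the scatter), an at least 1.3-fold higher number from compound 1 to compound 3 (0.12 log units; that floor lies within the scatter) and an at least 1.0-fold higher number from compound 2 to compound 3 (0.02 log units; that floor lies within the scatter). Those steps bear on the change to compound 4 only loosely, since here the sulfur itself is also replaced by oxygen and the ring is changed, a larger alteration than any of the three measured ones.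

With nothing in the shown data pointing to a gain or loss, the expected step of an at least 1.1-fold lower number from compound 3 to compound 4 (0.04 log units; that floor lies within the scatter) is none beyond the scatter, and the chance that this assay again reports only a limit is substantial. Compound 4 is therefore estimated at 180000 nM in this assay, with a range from 30000 nM to 600000 nM.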

Compound 4, half-maximal inhibitory concentration: 37000 nM
Compound 4: the middle estimate sits 4.9-fold (0.69 log units) above what was measured; the range from low to high includes it.
By their numbers in this assay, from the lowest: compound 4; then compounds 1 and 2 (each within the scatter of the next). At a limit, above all of these: compound 3.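

In this assay, putting (2-(trifluoromethyl)pyrimidin-4-yl)oxy on a saturated chain carbon bound to a carbonyl carbon moves the read-out beyond the scatter, which no exchange of one ring on the sulfur for another had done: a 5.1-fold lower number from compound 2 to compound 4 (0.71 log units; beyond the scatter) and a 4.1-fold lower number from compound 1 to compound 4 (0.61 log units; beyond the scatter). The comparison with compound 3 can be read only as a floor, an at least 5.4-fold lower number from compound 3 to compound 4 (0.73 log units; beyond the scatter) and the true step may be larger, because compound 3 stands at a limit of the assay: the limit of > 200000 nM in this assay, at which 1 of the 4 values shown sits. Compound 4 is therefore the strongest inhibitor of the four, showing that this position can respond to a change even though the earlier ring exchanges left the read-out within the scatter.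

This change replaces the sulfur with oxygen and the ring system at the same time, and the compounds shown do not separate the contribution of the linking atom from that of the ring or its trifluoromethyl group. A 2-(trifluoromethyl)pyrimidin-4-yl ring held on sulfur, a 1,3-benzoxazol-2-yl ring held on oxygen, or the same pyrimidine ring joined through an amine would each help to tell these apart.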